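Swapping Bromo for Cyano on the Aromatic Carbon

A few compounds are considered here, and "the series" means these few. Any claim that something is new, unique, unknown or untested is made for them only; others in the source may bear on it.

Two measured compounds share one core and differ only in the group on an aromatic carbon at one end. Compound 1 `CCc1ccc(NC(=O)c2csc(Cc3c(Cl)cccc3Cl)n2)cc1` carries an ethyl there, and in an assay on CHO cells, read by calcium flux (on this read-out higher numbers stand for weaker inhibition and lower numbers for stronger inhibition), compound 1 gives 810 nM. Compound 2 `O=C(Nc1ccc(Br)cc1)c1csc(Cc2c(Cl)cccc2Cl)n1` carries a bromo in its place, and in this assay compound 2 gives 400 nM. Among the compounds with values here, the single measured step, a 2.0-fold lower number from compound 1 to compound 2 (0.31 log units; beyond the scatter), is modest yet lies beyond the scatter. Within the data shown here, compound 2 thus stands lowest of the two numbers, with compound 1 as its only neighbour.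

Compound 3 `N#Cc1ccc(NC(=O)c2csc(Cc3c(Cl)cccc3Cl)n2)cc1` has not been measured. It differs from compound 2 by cyano in place of bromo on an aromatic carbon. Among the measured compounds shown here, only the step from compound 1 to compound 2 bears on this change. That step alters the same aromatic carbon, and its size was modest. A step of similar size is therefore expected here, with no firm direction, so the estimate means a 1.5-fold higher number from compound 2 to compound 3 (0.18 log units; within the scatter). Compound 3 is expected to give about 600 nM in this assay, within a range from 200 nM to 2000 nM.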

Compound 3, half-maximal inhibitory concentration: 450 nM
Compound 3: the middle estimate sits 1.3-fold (0.12 log units) above what was measured; measured number inside the range.
By their numbers in this assay, from the lowest: compounds 2, 3 and 1 (each within the scatter of the next, the first and the last beyond it).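

In this assay, going from 4-bromophenyl to 4-cyanophenyl gives a 1.1-fold higher number from compound 2 to compound 3 (0.05 log units; within the scatter), so at this aromatic carbon, para to a large group, a cyano with its two heavy atoms and one hydrogen-bond acceptor reads the same as a single bromine within the scatter. The cyano group cannot be told apart from ethyl either, with a 1.8-fold lower number from compound 1 to compound 3 (0.26 log units; within the scatter), even though bromo and ethyl do separate by a small margin, with a 2.0-fold lower number from compound 1 to compound 2 (0.31 log units; beyond the scatter); the three groups therefore sit in a narrow band, and compound 3 lies within the scatter of both of the others. Nothing available explains why these different groups give such close numbers.

The compounds shown leave open whether an amine, a carboxylic acid or a longer chain such as butyl on this same aromatic carbon would stay inside this narrow band or move the number well beyond the scatter. They also leave open whether cyano and bromo would still read alike on a different carbon of the ring, or with another change made to the shared core.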